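The compounds below may be only part of what the source reports. "The series", "measured", "known", "first", "only" and "open" are said of these compounds alone.

Series notes. Three compounds of the shared core carry a measurement in a functional assay on COLO 205 cells (Homo sapiens) for cytotoxicity, read by sulforhodamine B assay, with a stated time of 48 h, tested at 10 uM; a higher number here means a weaker effect of the compound at the concentration tested, a lower number a stronger effect. Compound 1 `COc1cc(C)cc(-c2c(-c3ccnc(-c4ccc(C(C)=O)cc4)c3)cnn2CC#N)c1` gives -67%. Compound 2 `COc1cc(C)cc(-c2nn(CC#N)cc2-c2ccc(-c3cccc(C(C)=O)c3)nc2)c1` gives -62%. Compound 3 `Cc1cc(O)cc(-c2nn(CC#N)cc2-c2ccnc(-c3ccc(Oc4ccccc4)cc3)c2)c1` gives -96%, the lowest of the three numbers; the nearest is compound 1, whose number stands higher by more than the scatter, and the furthest is compound 2, whose number stands higher still, also beyond the scatter. Compound 3 therefore shows the strongest effect of the three at the concentration tested.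

The next step leads to compound 4 `Cc1cc(O)cc(-c2nn(CC#N)cc2-c2ccnc(-c3ccc(N(C)C)cc3)c2)c1`, not yet measured. Among the compounds with values here, its change from compound 3: dimethylamino in place of phenoxy on an aromatic carbon No pair of measured compounds differs in one place, so nothing shows how an exchange on that aromatic carbon moves the read-out; the expectation rests on the change alone. With dimethylamino in place of phenoxy, a somewhat weaker effect is expected, and the step from compound 3 to compound 4 is estimated at a number 21 percentage points higher from compound 3 to compound 4 (beyond the scatter), upward and beyond the scatter. Compound 4 is expected to give -75% in this assay, within a range from -98% to -45%.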

Compound 4, a percentage reported as activity, at one concentration (the size of the read-out at that concentration, not a potency): -82%
For compound 4 the middle estimate is 7 percentage points above the measured one; the range from low to high includes it.
By their numbers in this assay, from the lowest: compound 3; then compound 4; then compounds 1 and 2 (each within the scatter of the next).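

In this assay, within the data shown here, the exchange of phenoxy for dimethylamino, on an aromatic carbon para to a large group, gives the first one-place comparison: a number 14 percentage points higher from compound 3 to compound 4 (beyond the scatter), a modest step. The aromatic ring of phenoxy is thus not required for a clear effect at this concentration, since compound 4, with dimethylamino and no ring in that group, still gives -82%. No measurement at hand accounts for the size of this step.

From the compounds shown here alone, with only phenoxy and dimethylamino at this aromatic carbon, the reading of other groups there remains open; a morpholine ring, a carboxylic acid or a methoxy group would extend the comparison. Also open, going by these compounds, is whether the same exchange moves the number by a like amount when the hydroxy group of compound 3 is replaced by methoxy.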